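The source may report more compounds than this note shows. Statements on the series, on what has been measured and on what is new or still open speak of the compounds shown alone.

Of the compounds shown here, three have been measured in a functional assay on SK-MEL-2 cells (Homo sapiens) for inhibition, read by sulforhodamine B assay, with a stated time of 48 h, tested at 10 uM; a higher number here means more inhibition of growth at the concentration tested, a lower number less inhibition of growth. Compound 1 `C/C(=N\O)c1ccc(NC(=O)Cn2nc(-c3ccc(Cl)cc3)nc2N)cc1` gives 15.3%, compound 3 `COc1cc(-c2nc3sc(-c4ccccc4)cn3n2)cc(OC)c1OC` gives 20%, and compound 2 `COc1ccc(-c2nc3sc(-c4ccccc4)cn3n2)cc1` gives 40%. Compound 2 therefore stands highest of the three, clearly beyond the scatter from both others. Compound 4 `c1ccc(-c2nc3sc(-c4ccccc4)cn3n2)cc1` keeps the core of compound 2 but has hydrogen in place of methoxy on an aromatic carbon. For the measured compounds named here, no measured pair shows this change alone, so the forecast is uncertain. Compounds 2 and 3 share a core and differ only in methoxy groups, yet their values lie apart. A modest fall in inhibition is expected, with an estimated a number 10 percentage points lower from compound 2 to compound 4 (within the scatter). For compound 4 the estimated value is 30%, with an expected range of 12% to 48%.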

Compound 4, percent growth inhibition at one concentration: 5%
Compound 4: middle estimate off by 25 percentage points, on the high side, outside the stated range (below it).
By their numbers in this assay, from the lowest: compound 4; then compounds 1 and 3 (each within the scatter of the next); then compound 2.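

For the compounds shown here, on the six-membered aromatic ring, para to a large group, the methoxy group matters in this assay: hydrogen in its place gives a number 35 percentage points lower from compound 2 to compound 4 (beyond the scatter), the first change that can be read on its own. Losing only these two heavy atoms leaves compound 4 with little of the inhibition that compound 2 shows. No measurement at hand accounts for this drop. It remains open whether methoxy itself is needed here, as the compounds shown do not tell how a hydroxyl, an ethoxy or an amine at this position would read.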